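Halogen swap on the benzyl group: from compound 2 to compound 3

A few compounds are considered here, and "the series" means these few. Any claim that something is new, unique, unknown or untested is made for them only; others in the source may bear on it.

Measured in a functional assay on MCF cells (Homo sapiens) for antiproliferative activity, with a stated time of 72 h; a higher number here means a weaker inhibitor, a lower number a stronger inhibitor:
Compound 1 `OC[C@H]1O[C@@H](n2cnc3c(NCc4ccc(F)cc4)ncnc32)[C@H](O)[C@@H]1O`: 21000 nM
Compound 2 `OC[C@H]1O[C@@H](n2cnc3c(NCc4ccc(Cl)cc4)ncnc32)[C@H](O)[C@@H]1O`: > 166000 nM (a limit, not a number)

Compound 2 stands at the limit of > 166000 nM in this assay, at which 1 of the 2 values shown sits. Compound 3 `OC[C@H]1O[C@@H](n2cnc3c(NCc4ccccc4Br)ncnc32)[C@H](O)[C@@H]1O` carries 2-bromophenyl in place of 4-chlorophenyl on a saturated chain carbon bound to a nitrogen on an aromatic ring. For the measured compounds named here, the only measured step that bears on this is an at least 7.9-fold higher number from compound 1 to compound 2 (0.89 log units; beyond the scatter), so a single halogen swap can matter here. Going by the values given here, no measured step moves the halogen to another place, so the guess is loose. A drop to a lower number is expected, similar in size to that step or smaller. The expected change is an at least 2.7-fold lower number from compound 2 to compound 3 (0.44 log units; beyond the scatter). For compound 3 the estimate is 60000 nM, with an expected range from 15000 nM to 170000 nM.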

Compound 3, half-maximal inhibitory concentration: > 166000 nM
Compound 3: no number, only a limit (the forecaster's own chance of this, stated with the estimate: 40%); at least 2.7-fold (0.44 log units) between middle value and limit.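

In this assay, compound 3 gives only a limit, not a number: > 166000 nM. Replacing 4-fluorophenyl with 2-bromophenyl gives an at least 7.9-fold higher number from compound 1 to compound 3 (0.89 log units; beyond the scatter), so a second halogen change on this ring also gives a weaker result, this time with a different halogen at a different place on the ring. Compound 2 and compound 3 cannot be compared, and the step between them cannot be read: the limit of > 166000 nM in this assay, at which 2 of the 3 values shown sit.

As far as these compounds go, because halogen and place change together in compound 3, the effect of each remains open. From the compounds shown here alone, it is also open how a plain phenyl or a methoxyphenyl would compare with the 4-fluorophenyl of compound 1.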